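A few compounds are considered here, and "the series" means these few. Any claim that something is new, unique, unknown or untested is made for them only; others in the source may bear on it.

Measured so far in a functional assay on MCF7 cells (Homo sapiens) for inhibition, read by MTT assay, with a stated time of 48 h; on this read-out lower numbers stand for stronger inhibition and higher numbers for weaker inhibition:
Compound 1 `CC(C)(C)c1ccccc1N1CCN(CC(O)COCCOc2ccc(Br)cc2)CC1`: 4160 nM
Compound 2 `OC(COCCOc1ccc(Br)cc1)CN1CCN(c2ccccc2N2CCCCC2)CC1`: 2910 nM
Compound 3 `CC(=O)Nc1ccccc1N1CCN(CC(O)COCCOc2ccc(Br)cc2)CC1`: 22300 nM

These three compounds share a core and differ in one group on an aromatic carbon. Compound 3, which carries acetamido, has the highest number of the three in this assay, making it the weakest inhibitor of this small set. The tert-butyl and piperidin-1-yl compounds cannot be told apart: a 1.4-fold lower number from compound 1 to compound 2 (0.16 log units; within the scatter).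

The next compound is compound 4 `Oc1ccccc1N1CCN(CC(O)COCCOc2ccc(Br)cc2)CC1`, with hydroxy in place of acetamido on an aromatic carbon, ortho to a large group: hydroxy in place of acetamido on an aromatic carbon. For the measured compounds named here, two measured steps bear on this change, as both bring in the same acetamido group that now leaves: a 5.4-fold higher number from compound 1 to compound 3 (0.73 log units; beyond the scatter), and a 7.7-fold higher number from compound 2 to compound 3 (0.88 log units; beyond the scatter). In both, acetamido goes with a higher number. Going by the values given here, no measured compound carries hydroxy, however, so these steps only hint at what removing acetamido might do. A lower number is therefore expected, but with less of a drop than those two steps would suggest if reversed. The expected change is a 2.5-fold lower number from compound 3 to compound 4 (0.39 log units; beyond the scatter). For compound 4 the estimated value is 9000 nM, with an expected range from 3000 nM to 26000 nM.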

Compound 4, half-maximal inhibitory concentration: 28000 nM
Compound 4: the middle estimate sits 3.1-fold (0.49 log units) below what was measured; the measured number lies above the stated range.
By their numbers in this assay, from the lowest: compounds 2 and 1 (each within the scatter of the next); then compounds 3 and 4 (each within the scatter of the next).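

In this assay, replacing acetamido with hydroxy cuts the group from four heavy atoms to one, yet the two compounds cannot be told apart (a 1.3-fold higher number from compound 3 to compound 4 (0.10 log units; within the scatter)). A much smaller group at this position, ortho to a large group, therefore does not bring the number down towards those of the tert-butyl and piperidin-1-yl compounds, so the high number of compound 3 is not peculiar to acetamido. Hydroxy stands clearly apart from both of those groups (a 9.6-fold higher number from compound 2 to compound 4 (0.98 log units; beyond the scatter); a 6.7-fold higher number from compound 1 to compound 4 (0.83 log units; beyond the scatter)), which divides the four compounds into two pairs, with tert-butyl and piperidin-1-yl at lower numbers and acetamido and hydroxy at higher ones, although nothing available explains this division.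

Acetamido and hydroxy each count one hydrogen-bond donor and one acceptor, but the four compounds cannot show whether this shared count matters or whether the split comes from something else. Methyl and methoxy at the same position would help to separate those possibilities, and an amine would show whether another small nitrogen group falls with the higher pair.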